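A few compounds are considered here, and "the series" means these few. Any claim that something is new, unique, unknown or untested is made for them only; others in the source may bear on it.

Of the compounds shown here, three built on one shared core have been tested in an assay on isolated protein for inhibition of polyamine deacetylase HDAC10 (Homo sapiens); on this read-out lower numbers stand for stronger inhibition and higher numbers for weaker inhibition. Compound 3 `COc1ccc(C(=O)c2ccc3c(ccn3S(=O)(=O)c3cccc(/C=C/C(=O)NO)c3)c2)cc1` gives 5890 nM in this assay, the lowest of the two numbers shown. Compound 1 `COc1cccc(C(=O)c2ccc3c(ccn3S(=O)(=O)c3cccc(/C=C/C(=O)NO)c3)c2)c1` gives 7740 nM in this assay, and a 1.3-fold lower number from compound 1 to compound 3 (0.12 log units; within the scatter), so these two cannot be told apart. For compound 2 `COc1cc(C(=O)c2ccc3c(ccn3S(=O)(=O)c3cccc(/C=C/C(=O)NO)c3)c2)cc(OC)c1OC` this assay reports only a limit and no number, > 100000 nM, namely (the limit of > 100000 nM in this assay, at which 1 of the 3 values shown sits). Against that limit, an at least 16-fold lower number from compound 2 to compound 3 (1.22 log units; beyond the scatter), and in the other direction an at least 12-fold higher number from compound 1 to compound 2 (1.11 log units; beyond the scatter).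

Compound 4 `COc1ccc(C(=O)c2ccc3c(ccn3S(=O)(=O)c3cccc(/C=C/C(=O)NO)c3)c2)cc1OC` has not yet been measured in this assay. It differs from compound 3 in one place: methoxy in place of hydrogen on an aromatic carbon. Two of the measured steps bear on this addition: both steps that lead to compound 2, where two further methoxy groups arrive together and the number rises beyond what the assay can report. Moving one methoxy group around the ring, as between compound 1 and compound 3, stays within the scatter. A single added methoxy group is expected to move part of the way toward compound 2. Compound 4 is therefore expected to show a 3.4-fold higher number from compound 3 to compound 4 (0.53 log units; beyond the scatter), toward weaker inhibition. Compound 4 is estimated at 20000 nM, with a range from 7000 nM to 70000 nM.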

Compound 4, half-maximal inhibitory concentration: 8240 nM
Compound 4: the middle estimate sits 2.4-fold (0.39 log units) above what was measured, and the stated range covers the measured number.
By their numbers in this assay, from the lowest: compounds 3, 1 and 4 (each within the scatter of the next). At a limit, above all of these: compound 2.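

In this assay, a methoxy group added to the ring of compound 3, ortho to its methoxy group, gives a 1.4-fold higher number from compound 3 to compound 4 (0.15 log units; within the scatter) and, against the other single-methoxy compound, a 1.1-fold higher number from compound 1 to compound 4 (0.03 log units; within the scatter), so the 3,4-dimethoxyphenyl group of compound 4 cannot be told apart from either single-methoxy group. Compound 2 remains a limit of the assay and not a number: the limit of > 100000 nM in this assay, at which 1 of the 4 values shown sits. Even so, removing just one of its methoxy groups gives an at least 12-fold lower number from compound 2 to compound 4 (1.08 log units; beyond the scatter), so the large step seen earlier does not need two added methoxy groups to be explained as a shared effect: the second added methoxy group, the third on the ring, is the one that accompanies it, while the first does not.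

On these data alone, what a hydroxy group, a chlorine atom or an amine would do at this place stays open, as does the number for a plain phenyl group on the carbonyl. The compounds shown also cannot say why the third methoxy group costs so much, or whether the same holds for a longer chain such as ethoxy.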